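This account rests on a few compounds, and the source may have more. Where it says the series, first, only, none or still open, it means among the compounds named here.

Within the data shown here, in an ADME assay on the whole organism (Rattus norvegicus, strain Wistar Han), at a dose of 0.5 mg/kg by the intravenous route (a higher number here means that the compound lasts longer, a lower number that the compound disappears faster), only two compounds have numbers so far: compound 1 (`COC(=O)N1c2ccc(C3(NC(=O)c4ccc(F)cc4)CC3)cc2[C@@H]2CC[C@@H]21`) gives 0.8 h and compound 2 (`O=C(C1CC1)N1CCc2nc(C3(C(=O)Nc4ccc(F)cc4)CCC3)ccc21`) gives 1.2 h as its reading. These two values lie within the usual scatter of each other, so the data cannot separate compound 1 from compound 2.

The next compound to be measured is compound 3 (`COC(=O)N1c2ccc(C3(NC(=O)c4ccc(F)cc4)CC3)cc2[C@H]2CC[C@H]21`), which has the same atoms and bonds as compound 1. The structural change is the two compounds have the same atoms and bonds and differ only in configuration as drawn: 2 of 2 stereo elements differ (all stereocentres are inverted: mirror images); a stereocentre at a saturated ring carbon is drawn S in compound 1 and R in compound 3; a stereocentre at a saturated ring carbon is drawn S in compound 1 and R in compound 3 and makes the two compounds mirror images, with both stereocentres at saturated ring carbons drawn S in compound 1 and R in compound 3.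

Among the measured compounds shown here, no pair of mirror images has been measured here, so no step is available as a guide. No change beyond the scatter is therefore expected in this assay in either direction. The estimate starts from compound 1 at 0.8 h as its anchor. The expected step is no change at the digits printed from compound 1 to compound 3 (within the scatter) and stays within the scatter. For compound 3 an estimated 0.8 h is expected, with 0.5 h to 1.3 h as the likely range.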

Compound 3, mean residence time: 1 h
For compound 3 the middle estimate is 1.3-fold (0.10 log units) below the measured one; the measured number falls inside the stated range.
By their numbers in this assay, from the lowest: compounds 1, 3 and 2 (each within the scatter of the next).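

In this assay, inverting both stereocentres gives a 1.3-fold higher number from compound 1 to compound 3 (0.10 log units; within the scatter), so this assay does not separate the two mirror images. Compared with the earlier comparison of compound 1 and compound 2, whose structures differ in many places, this pair isolates a single feature, the three-dimensional arrangement at the two saturated ring carbons: the fact that compounds 1 and 3 differ only in the configuration as drawn For this one pair, then, the mean residence time in the rat offers no basis for preferring one mirror image over the other, and choosing between them would have to rest on other data.

The compounds shown leave open what happens when only one of the two stereocentres is inverted, since that gives a different shape rather than a mirror image, and this pair says nothing about that case. They also leave open whether the mirror images would stay this close with a different group attached to the shared core, such as an amine or a carboxylic acid.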